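The source may report more compounds than this note shows. Statements on the series, on what has been measured and on what is new or still open speak of the compounds shown alone.

Measured compounds and their values:
- compound 1 `CCCN(CCC)Cc1ccc(Cl)c(-c2ccccc2OC)c1`: > 10000 nM
- compound 2 `COc1ccccc1-c1cc(C2CCN(C)C2)ccc1Cl`: 1000 nM
- compound 3 `CCCCNCc1ccc(Cl)c(-c2ccccc2OC)c1`: 360 nM

Among the compounds with values here, in an assay on isolated protein for binding affinity to 5-hydroxytryptamine receptor 5A (Homo sapiens) (a higher number here means a weaker inhibitor, a lower number a stronger inhibitor), compound 1 gives only a limit, > 10000 nM; no exact number is known for it, and it is the one compound among the three that sits at the limit of > 10000 nM in this assay, at which 1 of the 3 values shown sits. Compound 3 gives 360 nM in this assay, and compound 2 gives 1000 nM.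

The unmeasured compound 4 `CCN(CC)Cc1ccc(Cl)c(-c2ccccc2OC)c1` shares the core of compound 1 and differs from it in one place: diethylamino in place of dipropylamino on a saturated chain carbon bound to an aromatic carbon. Within the data shown here, the step that bears most directly on this change is the one from compound 1 to compound 3, an at least 27-fold lower number from compound 1 to compound 3 (1.44 log units; beyond the scatter), where dipropylamino was also replaced, there by butylamino. That step shows that shortening or trimming the amine on this saturated chain carbon can move the number a long way down. Diethylamino keeps two chains on the nitrogen, unlike butylamino, so the change toward compound 4 is smaller than the one toward compound 3. The step from compound 2 to compound 3, a 2.8-fold lower number from compound 2 to compound 3 (0.44 log units; beyond the scatter), concerns a different part of the molecule and adds little here.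

A modest improvement is therefore expected, with wide uncertainty since compound 1 has only a limit: the expected step is an at least 3.3-fold lower number from compound 1 to compound 4 (0.52 log units; beyond the scatter). Compound 4 is estimated at 3000 nM, within a range of 800 nM to 12000 nM.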

Compound 4, inhibition constant: 230 nM
Compound 4: the middle estimate sits 13-fold (1.12 log units) above what was measured; the whole stated range lies above it.
By their numbers in this assay, from the lowest: compounds 4 and 3 (each within the scatter of the next); then compound 2. At a limit, above all of these: compound 1.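

In this assay, replacing dipropylamino with diethylamino on this saturated chain carbon gives an at least 43-fold lower number from compound 1 to compound 4 (1.63 log units; beyond the scatter), so two chains on the nitrogen do not by themselves rule out a low number here, which compound 3, with its single butyl chain, could not show. Diethylamino and butylamino cannot be told apart at this position, with a 1.6-fold lower number from compound 3 to compound 4 (0.19 log units; within the scatter), while the comparison with the 1-methylpyrrolidin-3-yl group on the aromatic carbon gives a 4.3-fold lower number from compound 2 to compound 4 (0.64 log units; beyond the scatter). The value of compound 1 is a limit and not a number, so the true size of the first step remains unknown: the limit of > 10000 nM in this assay, at which 1 of the 4 values shown sits.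

The compounds shown leave open where the sharp change sets in between diethylamino and dipropylamino, a question that the mixed ethyl(propyl)amino group would address. They also leave open whether a smaller amine such as dimethylamino, or a ring amine such as piperidin-1-yl in the same place, would hold the number as low as diethylamino and butylamino do.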